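Two triazole pairs in an antiproliferative cell assay

The source may hold more compounds than are shown below. What is called first, only, known or untested is meant among the compounds shown, and "the series" means these compounds.

Compounds 1, 2 and 3 were tested in a functional assay on SW-620 cells (Homo sapiens) for antiproliferative activity, read by MTT assay, with a stated time of 72 h; a lower number here means a stronger inhibitor, a higher number a weaker inhibitor. Compound 2 `CCCCCCC#Cc1c(CCCCCC)oc2nc(=O)n(Cc3cn(Cc4ccccc4)nn3)cc12` gives 32600 nM in this assay. Compound 1 `CCCCCCC#Cc1c(CCCCCC)oc2nc(=O)n(Cc3cn(-c4ccc(Cl)cc4)nn3)cc12` reaches only a limit of the assay, > 100000 nM, so its value is a bound rather than a number. The step of an at least 3.0-fold higher number from compound 2 to compound 1 (0.48 log units; beyond the scatter) rests on the change (4-chlorophenyl in place of benzyl on an aromatic nitrogen); its true size is bounded by the limit of > 100000 nM in this assay, at which 1 of the 3 values shown sits. Compound 3 `O=c1nc2oc(CCCCl)cc2cn1Cc1cn(Cc2ccccc2)nn1`, built on a different core, gives 75500 nM in this assay; the difference between the core of compound 3 and that of compound 2 is not broken down here.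

Compound 4 `O=c1nc2oc(CCCCl)cc2cn1Cc1cn(-c2ccc(Cl)cc2)nn1` carries the same kind of change on the core of compound 3, namely (4-chlorophenyl in place of benzyl on an aromatic nitrogen), with the place described in the same words as for the pair of compounds 2 and 1. Judged by the step from compound 2 to compound 1, the step from compound 3 to compound 4 is expected to be a 2.9-fold higher number from compound 3 to compound 4 (0.46 log units; beyond the scatter) in this assay, and in size at least modest. Compound 4 is therefore estimated at 220000 nM, with a range from 100000 nM to 600000 nM in this assay, and most likely only a limit will be reported.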

Compound 4, half-maximal inhibitory concentration: > 100000 nM
Compound 4: only a limit was reported (the forecaster's own chance of this, stated with the estimate: 75%); the middle value does not contradict the limit.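

In this assay compound 4 reaches only a limit of the assay, > 100000 nM, and this is not a number. On the core of compound 3, 4-chlorophenyl in place of benzyl gives an at least 1.3-fold higher number from compound 3 to compound 4 (0.12 log units; that floor lies within the scatter), so this core does not contradict the rise seen on the core of compound 2 but does not by itself confirm a rise beyond the scatter, and both 4-chlorophenyl compounds end at the same limit: the limit of > 100000 nM in this assay, at which 2 of the 4 values shown sit. The change can therefore be said to carry over only loosely, and its size on the two cores cannot be compared: the same change on two cores in this assay, an at least 3.0-fold higher number (0.48 log units; beyond the scatter) from compound 2 to compound 1 and an at least 1.3-fold higher number (0.12 log units; that floor lies within the scatter) from compound 3 to compound 4; the limit leaves it open whether they differ.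

The compounds shown leave open how the two cores would respond to other groups on the same aromatic nitrogen, such as a plain phenyl or a 4-methoxyphenyl. They also leave open what an amine or a carboxylic acid on the chain of compound 3 would do in this assay.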